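This account rests on a few compounds, and the source may have more. Where it says the series, first, only, none or still open, it means among the compounds named here.

Compound 1 `COc1ccc2[nH]c(C(=O)N3CC(=O)N(Cc4ccccc4)[C@@H](COCc4ccccc4)C3)cc2c1` belongs to a small set examined in an ADME assay on Vero cells (Chlorocebus sabaeus) for cytotoxicity, with a stated time of 7 days; a higher number here means that more compound is tolerated, a lower number that less compound is tolerated. In this assay compound 1 gives > 30000 nM, which is a limit of the assay rather than a number. Compound 1 thus stands at the limit of > 30000 nM in this assay, at which 1 of the 2 values shown sits. Compound 2 `COc1cccc(CN2C(=O)CN(C(=O)c3cc4cc(OC)ccc4[nH]3)C[C@@H]2CC2CCCCC2)c1` gives > 10000 nM in this assay, again a limit rather than a measured number. Compound 2 stands at the limit of > 10000 nM in this assay, at which 1 of the 2 values shown sits. Neither result shows measurable toxicity within the range tested, so no ordering between them can be read. Compound 3 `COc1ccc2[nH]c(C(=O)N3CC(=O)N(Cc4ccccc4)[C@@H](CN4CC5CCCC5C4)C3)cc2c1` has not yet been measured. It differs from compound 1 in one place: a group of 8 heavy atoms (7 carbon, 1 nitrogen; one five-membered non-aromatic ring of carbon only, one five-membered non-aromatic ring with 1 hetero atom) in place of a group of 8 heavy atoms (7 carbon, 1 oxygen; one six-membered aromatic ring of carbon only), on a saturated chain carbon bound to a saturated ring carbon. For the measured compounds named here, no measured pair of compounds shows what such a change does in this assay, so the expectation rests only on compound 1 sitting at its limit. The step of an at least 1.2-fold lower number from compound 1 to compound 3 (0.07 log units; that floor lies within the scatter) is expected to be small and in no clear direction beyond the scatter. Compound 3 is therefore estimated at 25000 nM, with a range from 6000 nM to 60000 nM.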

Compound 3, half-maximal cytotoxic concentration: 10600 nM
For compound 3 the middle estimate is 2.4-fold (0.37 log units) above the measured one, and the stated range covers the measured number.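

For the compounds shown here, at this place, on a saturated chain carbon bound to a saturated ring carbon, replacing benzyloxy with the group of two five-membered non-aromatic rings gives the first readable number for toxicity in this assay. The change produces an at least 2.8-fold lower number from compound 1 to compound 3 (0.45 log units; beyond the scatter), so less compound is tolerated and this place is not indifferent to what it carries, even though the two groups match in heavy atoms. That step is only a floor, because compound 1 gives a limit of the assay rather than a number: the limit of > 30000 nM in this assay, at which 1 of the 3 values shown sits.

Going by these compounds, it remains open whether the ring nitrogen or the ring shape goes with the lower number, which a simple diethylamino group or a carboxylic acid at this place could help to separate. On these data alone, it is also open whether the same change would act alike with the other groups of compound 2.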